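The compounds below may be only part of what the source reports. "The series", "measured", "known", "first", "only" and "open" are said of these compounds alone.

The measured compounds:
compound 1, `O=S(=O)(CC1=NCCO1)c1c(-c2ccccc2)nn(-c2ccccc2)c1-c1ccccc1`, giving 59%
compound 2, `COc1ccc(C2=NOC(c3ccc(C)cc3)C2S(=O)(=O)CC2=NCCO2)cc1`, giving 65.9%
compound 3, `COc1ccc(C2=NOC(c3ccc(C)cc3)C2S(=O)(=O)CC2=NCCS2)cc1`, giving 54.1%

All three were tested in a functional assay, read by Griess assay, with a stated time of 150 min, tested at 75 ug/mL; a higher number here means a stronger effect of the compound at the concentration tested, a lower number a weaker effect. Compound 2 and compound 3 share a core and differ in one place, namely (a group of 5 heavy atoms (3 carbon, 1 nitrogen, 1 sulfur; one five-membered non-aromatic ring with 2 hetero atoms) in place of a group of 5 heavy atoms (3 carbon, 1 nitrogen, 1 oxygen; one five-membered non-aromatic ring with 2 hetero atoms), on a saturated chain carbon bound to a sulfonyl sulfur). That change brought a number 11.8 percentage points lower from compound 2 to compound 3 (beyond the scatter). Compound 1 rests on a different core, and the difference between the two cores is not broken down here. Its value in this assay and the values of compound 2 and compound 3 lie within the scatter of one another, so no order among the three is read from them.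

Compound 4, `O=S(=O)(CC1=NCCS1)c1c(-c2ccccc2)nn(-c2ccccc2)c1-c1ccccc1`, has not yet been measured in this assay. It stands to compound 1 as compound 3 stands to compound 2: the change is a group of 5 heavy atoms (3 carbon, 1 nitrogen, 1 sulfur; one five-membered non-aromatic ring with 2 hetero atoms) in place of a group of 5 heavy atoms (3 carbon, 1 nitrogen, 1 oxygen; one five-membered non-aromatic ring with 2 hetero atoms), on a saturated chain carbon bound to a sulfonyl sulfur, the same change as before, made at the same place on the other core. Because a number 11.8 percentage points lower from compound 2 to compound 3 (beyond the scatter) was a modest loss beyond the scatter, a loss of about the same size is expected here. Compound 4 is expected to show a number 12 percentage points lower from compound 1 to compound 4 (beyond the scatter). This rests on a single measured pair on a different core, so the expectation is loose. Compound 4 is thus expected to give about 47% in this assay, with a likely range from 35% to 59%.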

Compound 4, a percentage reported as activity, at one concentration (the size of the read-out at that concentration, not a potency): "not active" (no number reported)
Compound 4 has no reported number here, and the estimate cannot be compared.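

For the compounds shown here, compound 4 is reported as "not active" in this assay without a number, so no step from compound 1 to compound 4 can be read. Nothing shown here bears on this result. The compounds shown leave open how far the sulfur-containing group in place of the oxygen-containing group changes the effect on the core of compound 1, as a measured size.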